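The source may hold more compounds than are shown below. What is called first, only, known or untested is meant among the compounds shown, and "the series" means these compounds.

Measured so far:
compound 1, `CCCCCCCCNc1nc(SCc2ccc(C(F)(F)F)cc2)nc2ccccc12`, 10500 nM
compound 2, `CCOc1ccccc1Nc1nc(SCc2ccc(C(F)(F)F)cc2)nc2ccccc12`, 26200 nM
compound 3, `FC(F)(F)c1ccc(CSc2nc(Nc3cccc(Br)c3)c3ccccc3n2)cc1`, 8680 nM

In a functional assay on PC-3 cells (Homo sapiens) for cytotoxicity, read by MTT assay, with a stated time of 72 h (on this read-out higher numbers stand for weaker inhibition and lower numbers for stronger inhibition), compound 1 stands second highest of the three numbers, with compound 3 close to it (a 1.2-fold lower number from compound 1 to compound 3 (0.08 log units; within the scatter)) and compound 2 furthest from it (a 2.5-fold higher number from compound 1 to compound 2 (0.40 log units; beyond the scatter)). Compound 4, `COc1ccc(Nc2nc(SCc3ccc(C(F)(F)F)cc3)nc3ccccc23)cc1`, is not yet measured. It differs from compound 1 by 4-methoxyphenyl in place of octyl on a nitrogen on an aromatic ring. Going by the values given here, two measured steps bear on this, each swapping the octyl for an aryl group at the same nitrogen: a 2.5-fold higher number from compound 1 to compound 2 (0.40 log units; beyond the scatter) and a 1.2-fold lower number from compound 1 to compound 3 (0.08 log units; within the scatter). One is modest and upward, the other within the scatter, so for compound 4 a small step is expected in this assay, if anything toward a higher number, a 1.3-fold higher number from compound 1 to compound 4 (0.12 log units; within the scatter). Compound 4 is therefore estimated at 14000 nM, in the range 6000 nM to 32000 nM.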

Compound 4, half-maximal inhibitory concentration: 16700 nM
Compound 4: the middle estimate sits 1.2-fold (0.08 log units) below what was measured, within the range that was stated.
By their numbers in this assay, from the lowest: compounds 3, 1, 4 and 2 (each within the scatter of the next, the first and the last beyond it).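

In this assay the 4-methoxyphenyl group stays within the scatter of all three earlier groups on this nitrogen: a 1.6-fold higher number from compound 1 to compound 4 (0.20 log units; within the scatter) against octyl, a 1.9-fold higher number from compound 3 to compound 4 (0.28 log units; within the scatter) against 3-bromophenyl and a 1.6-fold lower number from compound 2 to compound 4 (0.20 log units; within the scatter) against 2-ethoxyphenyl. Compound 4 thus fills the one gap beyond the scatter that remains among the aryl groups, the gap between compound 2 and compound 3, and it does not separate from the octyl of compound 1. Nothing measured here accounts for this. The compounds shown leave open whether an amine or a carboxylic acid on the aromatic ring, or a shorter chain in place of octyl, would give a step beyond the scatter from compound 1.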